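The source may report more compounds than this note shows. Statements on the series, on what has been measured and on what is new or still open speak of the compounds shown alone.

Measured so far:
compound 1 `COCc1nc(C)c2cnnc(S)n12` — > 48000 nM
compound 2 `COCc1ncc2cnnc(S)n12` — > 48000 nM
compound 3 `CCCc1nc(C)c2c(C)nnc(S)n12` — 45000 nM

In a functional assay for inhibition, with Homo sapiens as the target (on this read-out higher numbers stand for weaker inhibition and lower numbers for stronger inhibition), compound 1 gives > 48000 nM, which is a limit of the assay and not a number. Compound 2 gives > 48000 nM in this assay, again a limit. Compound 3 is the only one of the three with a number, 45000 nM in this assay.

The change from compound 1 to compound 2 is hydrogen in place of methyl on an aromatic carbon. The step that the two limits leave unreadable from compound 1 to compound 2 cannot be read because the limit of > 48000 nM in this assay, at which 2 of the 3 values shown sit, leaves both ends open. The difference between the cores of compound 1 and compound 3 is not broken down here.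

Compound 4 `CCCc1ncc2c(C)nnc(S)n12`, not yet measured, carries the same kind of change from compound 3: hydrogen in place of methyl on an aromatic carbon. The place differs only in that the ring atom two ring bonds away bears a propyl group rather than a methoxymethyl group.

The step expected here is a 1.2-fold higher number from compound 3 to compound 4 (0.09 log units; within the scatter). That expectation rests on compound 3 sitting at 45000 nM, with the earlier pair giving no readable size. For compound 4 the estimate is 55000 nM, between 25000 nM and 150000 nM, with a fair chance that only a limit is returned.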

Compound 4, half-maximal inhibitory concentration: > 48000 nM
Compound 4: a limit, no number; the forecaster's own chance of this, stated with the estimate: 60%; the middle value is on the limit's open side.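

In this assay compound 4 gives > 48000 nM, which is a limit of the assay and not a number. On the core bearing the propyl group, hydrogen in place of methyl on an aromatic carbon gives an at least 1.0-fold higher number from compound 3 to compound 4 (0.02 log units; that floor lies within the scatter), so this pair offers only a floor and no size for the change. The same change on the core of compound 1 cannot be read, which leaves no size to carry from one core to the other and shows neither that the change behaves alike on both cores nor that it differs: the limit of > 48000 nM in this assay, at which 3 of the 4 values shown sit.

Going by these compounds alone, compound 3 remains the only compound with a number, at 45000 nM, so the series offers no second number to compare it with. Open, as far as these compounds go, is whether an amine or a carboxylic acid in place of the propyl group, or a longer chain there, would give a number on this read-out rather than a limit.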